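This account rests on a few compounds, and the source may have more. Where it says the series, first, only, none or still open, it means among the compounds named here.

Compound 1 `COc1cc(-c2nc(-c3ccccc3)[nH]c2-c2ccnc(NCCCNS(=O)(=O)c3ccc(F)cc3)n2)ccc1F`: 3960 nM
Compound 2 `COc1cc(-c2nc(-c3ccccc3)[nH]c2-c2ccnc(NCCCNS(=O)(=O)c3ccc(C(F)(F)F)cc3)n2)ccc1F`: 75200 nM
Compound 3 `COc1cc(-c2nc(-c3ccccc3)[nH]c2-c2ccnc(NCCCNS(=O)(=O)c3ccc(F)cc3)n2)ccc1Cl`: 4530 nM

These three compounds were compared in a functional assay on LOX IMVI cells (Homo sapiens) for cytotoxicity, read by MTT assay, with a stated time of 24 h; on this read-out higher numbers stand for weaker inhibition and lower numbers for stronger inhibition. Compound 2 differs from compound 1 by trifluoromethyl in place of fluoro on an aromatic carbon, and this gave a 19-fold higher number from compound 1 to compound 2 (1.28 log units; beyond the scatter). The core of compound 3 differs from that of compound 1 by chloro in place of fluoro on an aromatic carbon, a step of a 1.1-fold higher number from compound 1 to compound 3 (0.06 log units; within the scatter), so compound 1 and compound 3 lie within the scatter of each other. Compound 4 `COc1cc(-c2nc(-c3ccccc3)[nH]c2-c2ccnc(NCCCNS(=O)(=O)c3ccc(C(F)(F)F)cc3)n2)ccc1Cl` has not been measured; it differs from compound 3 by trifluoromethyl in place of fluoro on an aromatic carbon, the same change as from compound 1 to compound 2, at a place described in the same words. Because the same change produced a 19-fold higher number from compound 1 to compound 2 (1.28 log units; beyond the scatter), compound 4 is expected to show a step of an 18-fold higher number from compound 3 to compound 4 (1.25 log units; beyond the scatter) in this assay. Compound 4 is therefore estimated at 80000 nM, with a likely range from 30000 nM to 200000 nM.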

Compound 4, half-maximal inhibitory concentration: 1780 nM
Compound 4: middle estimate off by 45-fold (1.65 log units), on the high side; measured number below the stated range.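

In this assay, trifluoromethyl in place of fluoro did not carry from one core to the other, for the new step was a 2.5-fold lower number from compound 3 to compound 4 (0.41 log units; beyond the scatter), against the direction of the earlier one: the same change on two cores in this assay, a 19-fold higher number (1.28 log units; beyond the scatter) from compound 1 to compound 2 and a 2.5-fold lower number (0.41 log units; beyond the scatter) from compound 3 to compound 4, 48-fold (1.68 log units) apart, beyond the scatter of two such steps. Read the other way, chloro in place of fluoro, which made no difference beyond the scatter with the 4-fluorophenyl group, gave a 42-fold lower number from compound 2 to compound 4 (1.63 log units; beyond the scatter) with the 4-(trifluoromethyl)phenyl group: the same change on two cores in this assay, a 1.1-fold higher number (0.06 log units; within the scatter) from compound 1 to compound 3 and a 42-fold lower number (1.63 log units; beyond the scatter) from compound 2 to compound 4, 48-fold (1.68 log units) apart, beyond the scatter of two such steps. The two changes therefore do not act independently in these four compounds, but a single set of four cannot show why, nor whether compound 2 or compound 4 is the exception.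

As far as these compounds go, it remains open whether methoxy or nitrile in place of trifluoromethyl would follow compound 2 or compound 4. Also open, from the compounds shown here alone, is what a longer chain or an amide in place of the sulfonamide would do on either core.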